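This account rests on a few compounds, and the source may have more. Where it says the series, first, only, none or still open, it means among the compounds named here.

In a functional assay on SW480 cells (Homo sapiens) for cytotoxicity, read by MTT assay, with a stated time of 48 h (on this read-out higher numbers stand for weaker inhibition and lower numbers for stronger inhibition), compound 1 `COc1cc([C@@H]2C[C@@]2(CO)C(=O)Nc2ccccc2)cc(OC)c1OC` gives 76800 nM as a single number, while the two other measured compounds have several entries each. Compound 2 `CCOC(=O)C1(C(=O)NCc2ccccc2)CC1c1cc(OC)c(OC)c(OC)c1` shows 89600 nM; > 100000 nM (2 entries) in its entries. One entry of compound 2 is a limit of the assay. Compound 3 `CCOC(=O)C1(C(=O)NCc2ccc(F)cc2)CC1c1cc(OC)c(OC)c(OC)c1` shows 34100 nM; 28400 nM (2 entries) in its entries, so compound 1 stands above compound 3 on this scale. Compound 4 `COc1cc([C@H]2C[C@@]2(CO)C(=O)Nc2ccccc2)cc(OC)c1OC` differs from compound 1 by the two compounds have the same atoms and bonds and differ only in configuration as drawn: 1 of 2 stereo elements differ; a stereocentre at a saturated ring carbon is drawn S in compound 1 and R in compound 4 in configuration alone: a stereocentre at a saturated ring carbon is drawn S in compound 1 and R in compound 4. Going by the values given here, no measured pair here differs only in configuration. The expected step of a 1.1-fold lower number from compound 1 to compound 4 (0.04 log units; within the scatter) is therefore estimated to stay within the scatter, with no direction favoured. Compound 4 is expected at 70000 nM in this assay with a range from 30000 nM to 130000 nM as estimated.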

Compound 4, half-maximal inhibitory concentration: > 100000 nM
Compound 4: a limit, no number; the forecaster's own chance of this, stated with the estimate: 30%; middle value at least 1.4-fold (0.15 log units) away from the limit.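

In this assay compound 4 gives > 100000 nM, which is a limit of the assay and not a number. Read as a step, this is an at least 1.3-fold higher number from compound 1 to compound 4 (0.11 log units; that floor lies within the scatter), the only view so far of a change at this saturated ring carbon alone, and it does not settle whether drawing the stereocentre R rather than S matters. This pair isolates that one stereocentre: the fact that compounds 1 and 4 differ only in the configuration as drawn

Going by these compounds, the true size of the step stays open. So does whether the same change in configuration would count in a compound carrying a carboxylic acid or an amine on the shared core.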